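Geometric isomers of a glycosylated triazole series in DU-145

The source may hold more compounds than are shown below. What is called first, only, known or untested is meant among the compounds shown, and "the series" means these compounds.

Measured compounds:
compound 1 `CC(=O)OC[C@H]1O[C@@H](n2cc(CN3C(=O)/C(=C/c4ccc(N(C)C)cc4)c4ccccc43)nn2)[C@H](OC(C)=O)[C@@H](OC(C)=O)[C@@H]1OC(C)=O`: 11200 nM
compound 2 `CC(=O)OC[C@H]1O[C@@H](n2cc(CN3C(=O)/C(=C\c4ccco4)c4ccccc43)nn2)[C@H](OC(C)=O)[C@@H](OC(C)=O)[C@@H]1OC(C)=O`: 16900 nM

In a functional assay on DU-145 cells (Homo sapiens) for cytotoxicity, read by sulforhodamine B assay, with a stated time of 48 h (a lower number here means a stronger inhibitor, a higher number a weaker inhibitor), compound 1 gives 11200 nM and compound 2 gives 16900 nM. Compound 2 has the higher of the two numbers, but the two values lie within the scatter of each other, so neither can be called stronger. Compound 3 `CC(=O)OC[C@H]1O[C@@H](n2cc(CN3C(=O)/C(=C/c4ccco4)c4ccccc43)nn2)[C@H](OC(C)=O)[C@@H](OC(C)=O)[C@@H]1OC(C)=O` differs from compound 2 only in geometry: the two compounds have the same atoms and bonds and differ only in configuration as drawn: 1 of 6 stereo elements differ; a double bond is drawn Z in compound 2 and E in compound 3. Going by the values given here, no measured pair shows how this change acts here, so in this assay no step beyond the scatter is expected, in either direction. Compound 3 is therefore estimated at 15000 nM (range 5000 nM to 45000 nM), an expected step of a 1.1-fold lower number from compound 2 to compound 3 (0.05 log units; within the scatter).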

Compound 3, half-maximal inhibitory concentration: 10000 nM
Compound 3: the middle estimate sits 1.5-fold (0.18 log units) above what was measured; the range from low to high includes it.
By their numbers in this assay, from the lowest: compounds 3, 1 and 2 (each within the scatter of the next).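

Going by these compounds alone, this pair tests the geometry of the double bond on its own, which the earlier compounds could not do: the fact that compounds 2 and 3 differ only in the configuration as drawn. In this assay, going from Z to E gives a 1.7-fold lower number from compound 2 to compound 3 (0.23 log units; within the scatter), so this geometry makes no readable difference here. Exchanging the groups gives a 1.1-fold lower number from compound 1 to compound 3 (0.05 log units; within the scatter), so furan-2-yl and 4-(dimethylamino)phenyl cannot be told apart in this comparison either.

As far as these compounds go, whether geometry would matter with a different group at this position, such as a carboxylic acid or a pyridine ring, remains open. So does the effect of free hydroxyl groups in place of the acetate esters.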